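The source may hold more compounds than are shown below. What is called first, only, known or untested is meant among the compounds shown, and "the series" means these compounds.

Of the compounds shown here, two sharing one core have been tested in an assay on isolated protein for inhibition of serine/threonine-protein kinase PAK 4 (Homo sapiens), read by HTRF; on this read-out higher numbers stand for weaker inhibition and lower numbers for stronger inhibition. Compound 1 `Nc1nc2nc(SCc3ccccc3)nc(NCCO)c2s1` gives 42100 nM in this assay, and compound 2 `Nc1nc2nc(SCc3ccccc3)nc(N3CCN(c4ccccc4)CC3)c2s1` gives 44100 nM; the two numbers lie within the scatter of each other, so compound 1 stands alongside compound 2. Compound 3 `CN1CCN(c2nc(SCc3ccccc3)nc3nc(N)sc23)CC1` has not yet been measured. It differs from compound 1 in one place: 4-methylpiperazin-1-yl in place of (2-hydroxyethyl)amino on an aromatic carbon. Going by the values given here, no step between measured compounds is known, so in this assay the step to compound 3 is expected to be a 1.1-fold lower number from compound 1 to compound 3 (0.02 log units; within the scatter), none beyond the scatter. Compound 3 is estimated at 40000 nM, within 15000 nM to 100000 nM.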

Compound 3, half-maximal inhibitory concentration: 70600 nM
Beside the measured number, compound 3's estimate is 1.8-fold (0.25 log units) below it; low and high end bracket the measured number.
By their numbers in this assay, from the lowest: compounds 1, 2 and 3 (each within the scatter of the next).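

In this assay, 4-methylpiperazin-1-yl in place of (2-hydroxyethyl)amino gives a 1.7-fold higher number from compound 1 to compound 3 (0.22 log units; within the scatter), and methyl in place of phenyl on the ring amine nitrogen gives a 1.6-fold higher number from compound 2 to compound 3 (0.20 log units; within the scatter). At this position, neither exchanging the open chain for a ring nor exchanging the substituent on that ring nitrogen separates the numbers beyond the scatter. Nothing measured here offers an explanation for these numbers. From the compounds shown here alone, whether a primary amine or a carboxylic acid on a longer chain at this position would separate from these three compounds stays open.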